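Returning to a Benzyl Group on the Ring Nitrogen

The compounds below may be only part of what the source reports. "The series", "measured", "known", "first", "only" and "open" are said of these compounds alone.

Compound 1, `N#Cc1ccc(Cn2cc(C[C@H](O)COCCOC[C@@H](O)Cc3ccc(-c4ccccc4)cc3)nn2)cc1`, gives 7700 nM in a functional assay on SGC-7901 cells (Homo sapiens) for inhibition, read by MTT assay, with a stated time of 72 h; a higher number here means a weaker inhibitor of growth, a lower number a stronger inhibitor of growth.
Compound 2, `O[C@H](COCCOC[C@@H](O)Cc1cn(Cc2ccc(Oc3ccccc3)cc2)nn1)Cc1ccc(-c2ccccc2)cc1`, gives 4500 nM in this assay.
Compound 3, `O=C1COc2ccc(-n3cc(C[C@H](O)COCCOC[C@@H](O)Cc4ccc(-c5ccccc5)cc4)nn3)cc2N1`, gives 15200 nM in this assay.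

Compound 3 carries the highest of the three numbers, but compound 1 sits within the usual scatter of it, and only compound 2 lies clearly apart. Compound 4, `O[C@H](COCCOC[C@@H](O)Cc1cn(Cc2ccc(C(F)(F)F)cc2)nn1)Cc1ccc(-c2ccccc2)cc1`, is reached from compound 3 by a group of 11 heavy atoms (8 carbon, 3 fluorine; one six-membered aromatic ring of carbon only) in place of a group of 11 heavy atoms (8 carbon, 1 nitrogen, 2 oxygen; one six-membered non-aromatic ring with 2 hetero atoms, one six-membered aromatic ring of carbon only), on an aromatic nitrogen. Among the measured compounds shown here, two measured steps bear on this. The step of a 2.0-fold higher number from compound 1 to compound 3 (0.30 log units; within the scatter) is the reverse kind of change, a benzyl-type group giving way to the two-ring group; the step of a 1.7-fold lower number from compound 1 to compound 2 (0.23 log units; within the scatter) shows that exchanging the group on the benzyl ring moves little. Compound 4 therefore is expected to return toward the region of compounds 1 and 2, and the step of a 2.3-fold lower number from compound 3 to compound 4 (0.37 log units; beyond the scatter) is estimated to be a modest lowering, near the reverse of the step from compound 1 to compound 3. In this assay compound 4 is estimated at 6500 nM, within 2500 nM to 16000 nM.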

Compound 4, concentration for 50% growth inhibition: 8700 nM
For compound 4 the middle estimate is 1.3-fold (0.13 log units) below the measured one, within the range that was stated.
By their numbers in this assay, from the lowest: compounds 2, 1, 4 and 3 (each within the scatter of the next, the first and the last beyond it).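

In this assay, placing 4-(trifluoromethyl)benzyl on the aromatic nitrogen gives a number within the scatter of all three earlier compounds (a 1.7-fold lower number from compound 3 to compound 4 (0.24 log units; within the scatter); a 1.9-fold higher number from compound 2 to compound 4 (0.29 log units; within the scatter); a 1.1-fold higher number from compound 1 to compound 4 (0.05 log units; within the scatter)). Trifluoromethyl thus joins cyano and phenoxy as a third group on the benzyl ring with no step beyond the scatter, and compound 4 is within the scatter of both compound 2 and compound 3, which themselves lie beyond it. Nothing here gives a reason for these small differences.

On these data alone, whether an amine or a carboxylic acid on the benzyl ring would move the number beyond the scatter stays open, as does the effect of a longer chain in place of the benzyl carbon. All four compounds share the same core, so they do not show what a change there would do.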